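This account rests on a few compounds, and the source may have more. Where it says the series, first, only, none or still open, it means among the compounds named here.

Measured compounds:
- Compound 1, `CN1CCN(C(=S)SCCCOc2ccc(C(=O)/C=C/c3ccc(Cl)cc3)cc2)CC1`: 31900 nM
- Compound 2, `O=C(/C=C/c1cccs1)c1ccc(OCCSC(=S)N2CCCC2)cc1`: 19100 nM

Both were tested in a functional assay on SK-N-SH cells (Homo sapiens) for inhibition, read by MTT assay, with a stated time of 72 h; a lower number here means a stronger inhibitor, a higher number a weaker inhibitor. Compound 1, with 31900 nM, has the highest number of the two. Its nearest neighbour is compound 2, which in this assay gives 19100 nM; the gap between the two lies within the scatter, so the two numbers cannot be told apart.

The next compound, compound 3, `COc1cc(/C=C/C(=O)c2ccc(OCCCSC(=S)N3CCN(C)CC3)cc2)cc(OC)c1OC`, has not yet been measured. It differs from compound 1 in one place: 3,4,5-trimethoxyphenyl in place of 4-chlorophenyl on a double-bonded chain carbon bound to a double-bonded chain carbon. Within the data shown here, no step between two measured compounds corresponds to this change, so there is nothing in the measured pairs to lean on, and the expectation rests on the size of the change alone.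

For this assay a step toward a lower number is expected, of a size somewhat beyond the scatter, as a 2.7-fold lower number from compound 1 to compound 3 (0.42 log units; beyond the scatter). The value of compound 3 is accordingly estimated at 12000 nM, with a range from 3000 nM to 45000 nM.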

Compound 3, half-maximal inhibitory concentration: 2030 nM
Compound 3: middle estimate off by 5.9-fold (0.77 log units), on the high side; the measured number lies below the stated range.
By their numbers in this assay, from the lowest: compound 3; then compounds 2 and 1 (each within the scatter of the next).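

In this assay, the place on a double-bonded chain carbon bound to a double-bonded chain carbon proves highly sensitive to what it carries: with the rest of the core of compound 1 unchanged, 3,4,5-trimethoxyphenyl in place of 4-chlorophenyl gives a 16-fold lower number from compound 1 to compound 3 (1.20 log units; beyond the scatter) and nothing else differs between the two. Among these compounds, compound 1 and compound 2 differ in more than one place and their numbers could not be told apart, so this is the first reading of any single position, and it places a group with 3 hydrogen-bond acceptors where the group that leaves has 0. Among the compounds shown here, nothing available here shows why this change lowers the number so far.

The compounds shown leave open whether all three methoxy groups are needed, as a simpler group such as 4-methoxyphenyl, or an unsubstituted phenyl, would separate the contribution of the methoxy groups from that of losing the chlorine. They also leave open whether the same exchange would lower the number to a similar degree on the core of compound 2.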